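A few compounds are considered here, and "the series" means these few. Any claim that something is new, unique, unknown or untested is made for them only; others in the source may bear on it.

The measured compounds:
Compound 1, `CC1=C(C(=O)OCc2ccccn2)C(c2ccc([N+](=O)[O-])cc2)C2=C(CCCC2=O)N1`, which in a physicochemical assay for lipophilicity, measured as octanol-water partition (a lower number here means a more polar compound, a higher number a more lipophilic compound), gives 1.88.
Compound 2, `CC1=C(C(=O)OCc2ccccn2)C(c2cccs2)C2=C(CCCC2=O)N1`, which in this assay gives 1.77.

Compound 2 holds the lowest of the two numbers, and its nearest neighbour is compound 1, a number higher only within the scatter. Within the data shown here, the one measured step, a number 0.11 log units lower from compound 1 to compound 2 (within the scatter), is the only comparison available and it did not move the read-out beyond the scatter.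

Compound 3, `CC1=C(C(=O)OCc2ccccn2)C(c2ccccc2[N+](=O)[O-])C2=C(CCCC2=O)N1`, has not yet been measured. Its change from compound 2 is 2-nitrophenyl in place of thiophen-2-yl on a saturated ring carbon. This step bears a close relation to the measured one: a nitrophenyl group again takes the place of thiophen-2-yl on the same saturated ring carbon, the nitro group now standing in a different position on the six-membered ring. Since the step from compound 1 to compound 2 lay within the scatter, the reverse kind of exchange is expected to stay within the scatter as well, with compound 3 coming out near compound 1. Compound 3 is therefore estimated at 1.85, with a range from 1.55 to 2.15. The step this expectation implies, a number 0.08 log units higher from compound 2 to compound 3 (within the scatter), is expected to be within the scatter.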

Compound 3, partition coefficient: 1.88
Beside the measured number, compound 3's estimate is 0.03 log units below it; the range from low to high includes it.
By their numbers in this assay, from the lowest: compounds 2, 1 and 3 (each within the scatter of the next).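

With 2-nitrophenyl, this saturated ring carbon has now carried three different aromatic groups, and this assay does not tell them apart: the exchange for thiophen-2-yl gives a number 0.11 log units higher from compound 2 to compound 3 (within the scatter) and thus adds a second ring exchange at this carbon that stays inside the scatter. The earlier compounds shown here also held the nitro group at a single place on the six-membered ring, whereas 2-nitrophenyl in place of 4-nitrophenyl now gives no change at the digits printed from compound 1 to compound 3 (within the scatter) and so shows that this shift of the nitro group leaves the read-out unchanged at the digits printed. Nothing measured alongside these numbers bears on why the three compounds fall so close together.

From the compounds shown here alone, all three groups at this carbon are aromatic rings, so it remains open whether an amine, a carboxylic acid or a longer alkyl chain in their place would move the read-out beyond the scatter. Also open, going by these compounds, is whether 3-nitrophenyl would fall with the other two, and whether this insensitivity holds with a different ester on the shared core.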